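Chloro to Fluoro Swap at Two Places in One Series

The source may hold more compounds than are shown below. What is called first, only, known or untested is meant among the compounds shown, and "the series" means these compounds.

Of the compounds shown here, three of one series have been tested in a functional assay on HL-60 cells (Homo sapiens) for cytotoxicity, read by MTT assay, with a stated time of 48 h; a higher number here means a weaker inhibitor, a lower number a stronger inhibitor. Compound 1 `O=C(O)CN1C(=O)/C(=C/c2nc3ccccc3n2Cc2ccc(F)cc2)SC1=S` gives 1420 nM, compound 2 `O=C(O)CN1C(=O)/C(=C/c2nc3ccccc3n2Cc2ccc(Cl)cc2)SC1=S` gives 2650 nM, and compound 3 `O=C(O)CN1C(=O)/C(=C/c2nc3ccc(Cl)cc3n2Cc2ccccc2F)SC1=S` gives 5230 nM. Compound 2 and compound 1 differ in a single place: fluoro in place of chloro on an aromatic carbon. That change gave a 1.9-fold lower number from compound 2 to compound 1 (0.27 log units; within the scatter). The core of compound 3 differs from the core of compound 2, but that difference is not broken down here. Compound 4 `O=C(O)CN1C(=O)/C(=C/c2nc3ccc(F)cc3n2Cc2ccccc2F)SC1=S`, still to be measured in this assay, carries the same kind of change relative to compound 3: fluoro in place of chloro on an aromatic carbon. The surroundings are not the same: in compound 1 the fluoro sits para to a large group, whereas in compound 4 it sits on a ring that is part of a fused or bridged system of two rings, meta to a fused ring and para to a fused ring. For the measured compounds named here, compound 4 is expected to show a 1.5-fold lower number from compound 3 to compound 4 (0.17 log units; within the scatter), a step of roughly the earlier size, because the only comparable change on record is a 1.9-fold lower number from compound 2 to compound 1 (0.27 log units; within the scatter). The estimate for compound 4 is 3500 nM, between 1500 nM and 9000 nM.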

Compound 4, half-maximal inhibitory concentration: 5230 nM
Compound 4: middle estimate off by 1.5-fold (0.17 log units), on the low side; the range from low to high includes it.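

In this assay, putting fluoro in place of chloro on an aromatic carbon of the core of compound 3 gave no change at the digits printed from compound 3 to compound 4 (within the scatter). Set beside the earlier case, the two steps do not differ: the same change on two cores in this assay, a 1.9-fold lower number (0.27 log units; within the scatter) from compound 2 to compound 1 and no change at the digits printed (within the scatter) from compound 3 to compound 4, 1.9-fold (0.27 log units) apart, within the scatter of two such steps This shows that, across these two pairs, the swap moved the number by no more than the scatter on either core, but it does not show that the swap has a real effect on either core, or that it would behave the same way on any other core, and since the swap sits at a different place in each pair, core and place cannot be told apart.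

The compounds shown leave open how a methoxy group, an amine or a nitrile on the same aromatic carbon would compare with chloro and fluoro. They also leave open what a longer chain carrying the carboxylic acid would do to the number on either core.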